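From Compound 3 to Compound 4: One Aryl Group Swapped

This account rests on a few compounds, and the source may have more. Where it says the series, first, only, none or still open, it means among the compounds named here.

Of the compounds shown here, three sharing one core have been tested in an ADME assay on Vero cells (Chlorocebus sabaeus) for cytotoxicity, read by neutral red uptake, tested at 3150 ug/mL; a lower number here means a stronger effect, a higher number a weaker effect of the compound at the concentration tested. Compound 1 `O=C1CSC(c2c(Cl)cccc2Cl)N1CCN1CCCCC1` gives 7%. Compound 2 `COc1ccc(C2SCC(=O)N2CCN2CCCCC2)cc1` gives 11%. Compound 3 `O=C1CSC(c2cccc(Cl)c2)N1CCN1CCCCC1` gives 15%, which is the highest of the three numbers on paper, yet the gap to compound 2 and the larger gap to compound 1 both fall within the usual scatter of repeated measurements, so the three values cannot be told apart in this assay. All three read as weak effects at the concentration tested.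

Compound 4 `O=C1CSC(c2ccc(O)cc2)N1CCN1CCCCC1` has not yet been measured. It differs from compound 3 in one place: 4-hydroxyphenyl in place of 3-chlorophenyl on a saturated ring carbon. For the measured compounds named here, with no measured pair of this series differing in a single place, there is no step to lean on; what the data show is that three different aryl groups on this carbon all sit in the same low band. The expected step of a number 2 percentage points lower from compound 3 to compound 4 (within the scatter) is therefore none beyond the scatter. Because compound 3 gives 15%, compound 4 is expected to give about 13%, within a range from 3% to 25%.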

Compound 4, a percentage reported as activity, at one concentration (the size of the read-out at that concentration, not a potency): 10%
For compound 4 the middle estimate is 3 percentage points above the measured one; the range from low to high includes it.
By their numbers in this assay, from the lowest: compounds 1, 4, 2 and 3 (each within the scatter of the next).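

In this assay, 4-hydroxyphenyl in place of 3-chlorophenyl on the saturated ring carbon gives a number 5 percentage points lower from compound 3 to compound 4 (within the scatter). At this position, then, an aryl group with a hydrogen-bond donor and a hydrogen-bond acceptor cannot be told apart from one with neither, even with oxygen entering and chlorine leaving. Compound 4 also supplies the first pair with a very small difference, hydrogen in place of methyl on an oxygen on an aromatic ring, and this gives a number 1 percentage points lower from compound 2 to compound 4 (within the scatter), so capping that oxygen makes no difference that can be read here, and no measurement shown explains either step.

The aryl groups shown are all six-membered aromatic rings of carbon only, so it remains open whether a carboxylic acid or an amine on that ring, or a plain alkyl chain in place of the ring, would stay within the scatter of these compounds. The rest of the shared core is the same throughout, so these compounds cannot show how changes there would affect the read-out.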